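A few compounds are considered here, and "the series" means these few. Any claim that something is new, unique, unknown or untested is made for them only; others in the source may bear on it.

Of the compounds shown here, three have been measured in an assay on isolated protein for inhibition of Amine oxidase [flavin-containing] A (Homo sapiens), read by fluorescence, with stated times of 10 min, 10 s and 20 min; a lower number here means a stronger inhibitor, a higher number a weaker inhibitor. Compound 1 `CCN(CC)C(=O)Nc1ccc2cc[nH]c2c1` gives 20400 nM. Compound 2 `CCN(CC)C(=O)Oc1ccc2cc[nH]c2c1` gives 88100 nM in this assay, the highest number of the three; how the core of compound 2 differs from the core of compound 1 is not broken down here. Compound 3 `C#CCn1ccc2ccc(NC(=O)N(CC)CC)cc21` is compound 1 with a single change, (propargyl in place of hydrogen on an aromatic nitrogen), and in this assay compound 3 gives 4310 nM. Within the measured set that change produced a 4.7-fold lower number from compound 1 to compound 3 (0.68 log units; beyond the scatter), a step that lies beyond the usual scatter of repeated measurements.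

Compound 4 `C#CCn1ccc2ccc(OC(=O)N(CC)CC)cc21` has not yet been measured. Within the data shown here, it is compound 2 carrying the change (propargyl in place of hydrogen on an aromatic nitrogen), the same change and at the same place as the one made from compound 1 to compound 3. Because the earlier example of this change gave a 4.7-fold lower number from compound 1 to compound 3 (0.68 log units; beyond the scatter), compound 4 is expected to stand lower than compound 2 by a step of about a 4.6-fold lower number from compound 2 to compound 4 (0.67 log units; beyond the scatter). The expectation rests on one earlier example only, so a wide range is allowed. Compound 4 is estimated at 19000 nM, from 6000 nM to 60000 nM.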

Compound 4, half-maximal inhibitory concentration: 51600 nM
Beside the measured number, compound 4's estimate is 2.7-fold (0.43 log units) below it, within the range that was stated.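

Putting propargyl in place of hydrogen on the aromatic nitrogen of compound 2 gave, in this assay, a 1.7-fold lower number from compound 2 to compound 4 (0.23 log units; within the scatter), so on this core the change has no clear effect. The size of the step therefore did not carry over intact from one core to the other, and the gap between the two steps is larger than chance variation would readily explain: the same change on two cores in this assay, a 4.7-fold lower number (0.68 log units; beyond the scatter) from compound 1 to compound 3 and a 1.7-fold lower number (0.23 log units; within the scatter) from compound 2 to compound 4, 2.8-fold (0.44 log units) apart, beyond the scatter of two such steps This shows that, for these two pairs, what the change does depends on the core it is made on, but two examples give no general rule for other cores and do not explain why the steps differ.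

The compounds shown leave open whether other groups on the same aromatic nitrogen, such as a methyl, an allyl or a longer chain ending in an amine, would also give steps that differ between the two cores. They also leave open how the propargyl change would behave on a third core.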